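The compounds below may be only part of what the source reports. "The series", "measured", "known", "first", "only" and "open" are said of these compounds alone.

Compound 1 `Cc1cc(-c2ccsc2)c2ncc(CSCCc3ccccc3)n2c1` and compound 2 `COc1cccc(-c2cc(C)c3ncc(CSCCc4ccccc4)n3c2)c1` carry the same core with a different aryl group. In an ADME assay on HEL cells (Homo sapiens) for cytotoxicity, with a stated time of 3 days (a higher number here means that more compound is tolerated, a lower number that less compound is tolerated), compound 1 gives 100 ug/mL. In this assay compound 2 gives 20 ug/mL, the lowest of the two numbers seen, a gap to compound 1 beyond the scatter. Compound 3 `Cc1cc(-c2cccc(O)c2)cn2c(CSCCc3ccccc3)cnc12` is not yet measured. Its change from compound 2 is small: hydrogen in place of methyl on an oxygen on an aromatic ring. Among the compounds with values here, no measured pair shows this change, so the step of a 1.8-fold higher number from compound 2 to compound 3 (0.24 log units; within the scatter) is expected to be modest, toward more compound tolerated, or none beyond the scatter. For compound 3 in this assay the estimate is 35 ug/mL, in the range 15 ug/mL to 100 ug/mL.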

Compound 3, minimum cytotoxic concentration: 20 ug/mL
Compound 3: the middle estimate sits 1.8-fold (0.24 log units) above what was measured; the measured number falls inside the stated range.
By their numbers in this assay, from the lowest: compounds 2 and 3 (each within the scatter of the next); then compound 1.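

In this assay, within the data shown here, replacing methoxy with hydroxy gives no change at the digits printed from compound 2 to compound 3 (within the scatter), the first reading of this change. On this 3-substituted phenyl group, the methyl on the oxygen can therefore go without a shift beyond the scatter. No measurement shown bears on why the two compounds match.

Still open, as far as these compounds go, is whether an amine or a carboxylic acid in place of the hydroxy, or ethoxy as a longer chain on the oxygen, would read the same way in this assay. The same change on other aryl groups also remains untested among these compounds.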